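Moving the Fluorine Around the Ring on Compound 1

The source may hold more compounds than are shown below. What is called first, only, known or untested is meant among the compounds shown, and "the series" means these compounds.

Among the compounds with values here, in a functional assay on HeLa cells (Homo sapiens) for cytotoxicity, read by MTT assay, with a stated time of 48 h (on this read-out lower numbers stand for stronger inhibition and higher numbers for weaker inhibition), compound 1 `C=C1OC(=O)C=C1Cc1ccc(NC(=O)/C=C/c2ccc(F)cc2)cc1` gives 2770 nM, the lowest of the three numbers so far. Its nearest neighbour is compound 3 `C=C1OC(=O)C=C1Cc1ccc(NC(=O)/C=C/c2ccccc2)cc1`, which gives 7340 nM. The step of a 2.6-fold higher number from compound 1 to compound 3 (0.42 log units; beyond the scatter) shows that simply removing the fluoro raises the number beyond the scatter. Furthest away stands compound 2 `C=C1OC(=O)C=C1Cc1ccc(NC(=O)c2ccccc2)cc1` with 48300 nM, and the step of a 6.6-fold lower number from compound 2 to compound 3 (0.82 log units; beyond the scatter) shows how much the 2-phenylethenyl group lowers the number relative to phenyl.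

Compound 4 `C=C1OC(=O)C=C1Cc1ccc(NC(=O)/C=C/c2cccc(F)c2)cc1` has not yet been measured. It differs from compound 1 in one place: 3-fluorophenyl in place of 4-fluorophenyl on a double-bonded chain carbon bound to a double-bonded chain carbon. Within the data shown here, the fluorine stays on the same ring, but no measured pair speaks directly to exchanging 4-fluorophenyl for 3-fluorophenyl. Among the measured compounds shown here, the only step that bears on it at all is a 2.6-fold higher number from compound 1 to compound 3 (0.42 log units; beyond the scatter), where the fluoro was removed altogether, a modest change. Keeping the fluorine while relocating it is expected to matter less than losing it, so the step of a 1.3-fold higher number from compound 1 to compound 4 (0.11 log units; within the scatter) is expected to be small, at most a slightly higher number and possibly nothing beyond the scatter. For compound 4 the estimated value is 3600 nM, with a likely range from 1500 nM to 8500 nM.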

Compound 4, half-maximal inhibitory concentration: 30200 nM
Compound 4: the middle estimate sits 8.4-fold (0.92 log units) below what was measured; the whole stated range lies below it.
By their numbers in this assay, from the lowest: compound 1; then compound 3; then compounds 4 and 2 (each within the scatter of the next).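

In this assay, within the data shown here, this ring proves far more sensitive to where the fluoro sits than the earlier compounds could show: exchanging 4-fluorophenyl for 3-fluorophenyl gives an 11-fold higher number from compound 1 to compound 4 (1.04 log units; beyond the scatter), a large step, whereas removing the fluoro altogether gives the modest 2.6-fold higher number from compound 1 to compound 3 (0.42 log units; beyond the scatter). The fluoro also has no single direction of effect across these compounds, since the lower number of compound 1 relative to compound 3 is reversed by the 3-fluorophenyl group, with a 4.1-fold higher number from compound 3 to compound 4 (0.61 log units; beyond the scatter). Nothing available here accounts for this split between the two placements.

Going by these compounds, it remains open whether a chloro or a methoxy group in place of the fluoro would show the same split between the two placements, or whether this sensitivity belongs to the fluoro alone. Also open, on these data alone, is whether the gap between 4-fluorophenyl and 3-fluorophenyl would persist with the arrangement of compound 2, where phenyl rather than 2-phenylethenyl stands on the carbonyl carbon.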